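The source may report more compounds than this note shows. Statements on the series, on what has been measured and on what is new or still open speak of the compounds shown alone.

Compound 1 `OC[C@]1(c2ccc(F)cc2)NC[C@H](O)[C@H]1O` and compound 2 `Cc1ccc([C@]2(CO)NC[C@@H](O)[C@@H]2O)cc1` share one core and differ only in the group on the aromatic ring. In an assay on isolated protein for inhibition of lysosomal alpha-glucosidase (Homo sapiens), tested at 1000 uM (on this read-out higher numbers stand for more inhibition at the one concentration tested (going by the name of the read-out) and lower numbers for less inhibition), compound 1 gives 8.3%, while compound 2 gives 21.3%, the higher of the two numbers and a gap beyond the usual scatter. Compound 3 `COc1ccc([C@]2(CO)NC[C@@H](O)[C@@H]2O)cc1` carries methoxy in place of methyl on an aromatic carbon. Among the compounds with values here, no measured pair shows what such a swap does, so in this assay only a modest step is expected, in either direction or none beyond the scatter. Compound 3 is therefore estimated at 18%, between 5% and 35%, which would mean a number 3.3 percentage points lower from compound 2 to compound 3 (within the scatter).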

Compound 3, a percentage reported as inhibition, at one concentration (the size of the read-out at that concentration, not a potency): 40.2%
Estimate against measurement, compound 3: 22.2 percentage points below; the whole stated range lies below it.
By their numbers in this assay, from the lowest: compound 1; then compound 2; then compound 3.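

In this assay, methoxy in place of methyl on an aromatic carbon gives a number 18.9 percentage points higher from compound 2 to compound 3 (beyond the scatter). Within the data shown here, this is the first measured swap of this kind, and it shows that adding one oxygen, a hydrogen-bond acceptor, at this position goes with a change beyond the scatter. Nothing available explains this rise.

The compounds shown leave open whether the oxygen itself or the larger group accounts for the change. They also leave open what an ethoxy group or an amine on the same aromatic carbon would give.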